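Swapping Dimethylamino for Methylsulfanyl on an Ethynyl Nucleoside

This account rests on a few compounds, and the source may have more. Where it says the series, first, only, none or still open, it means among the compounds named here.

Three measured compounds share a sugar-bearing core and differ at one carbon of the five-membered ring. Compound 1 `CN(C)c1ncnc2c1c(-c1ccoc1)cn2[C@@H]1O[C@H](CO)[C@@H](O)[C@H]1O` carries furan-3-yl there, and in a functional assay on HCT-116 cells (Homo sapiens), read by MTT assay, with a stated time of 72 h (on this read-out higher numbers stand for weaker inhibition and lower numbers for stronger inhibition), compound 1 gives only the limit > 20000 nM. Compound 3 `CN(C)c1ncnc2c1c(-c1cccs1)cn2[C@@H]1O[C@H](CO)[C@@H](O)[C@H]1O` carries thiophen-2-yl, and in this assay compound 3 likewise gives only the limit > 20000 nM. Within the data shown here, compound 2 `C#Cc1cn([C@@H]2O[C@H](CO)[C@@H](O)[C@H]2O)c2ncnc(N(C)C)c12` carries ethynyl and is the only compound with a real number: in this assay compound 2 gives 180 nM. The steps of an at least 110-fold lower number from compound 1 to compound 2 (2.04 log units; beyond the scatter) and an at least 110-fold higher number from compound 2 to compound 3 (2.04 log units; beyond the scatter) are both large, while a step that the two limits leave unreadable from compound 1 to compound 3 follows because both of its ends sit at the limit of > 20000 nM in this assay, at which 2 of the 3 values shown sit.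

Compound 4 `C#Cc1cn([C@@H]2O[C@H](CO)[C@@H](O)[C@H]2O)c2ncnc(SC)c12` keeps the ethynyl and alters a different part of the core: methylsulfanyl in place of dimethylamino on an aromatic carbon. Among the measured compounds shown here, no measured step touches this position, so none bears directly on the change; the measured steps show only that the ethynyl carrier is the one that yields a number. The expected step of a 2.8-fold higher number from compound 2 to compound 4 (0.44 log units; beyond the scatter) is therefore taken as a modest weakening, possibly none beyond the scatter. Compound 4 is estimated at 500 nM, with a range from 100 nM to 3000 nM.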

Compound 4, half-maximal inhibitory concentration: 30 nM
Estimate against measurement, compound 4: 17-fold (1.22 log units) above, outside the stated range (below it).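

Among these compounds, the earlier compounds varied only one carbon of the five-membered ring, so this is the first view of the aromatic carbon on the six-membered aromatic ring. In this assay, methylsulfanyl in place of dimethylamino gives a 6.0-fold lower number from compound 2 to compound 4 (0.78 log units; beyond the scatter), so with ethynyl held fixed, activity in these cells does not depend on dimethylamino, and this position can shift potency modestly. Nothing shown here accounts for why the step runs in this direction.

Only these two groups are shown at this position, so it remains open how an amino group, a methoxy group or a longer chain such as ethylsulfanyl would compare. From the compounds shown here alone, it is also open whether methylsulfanyl would give a readable number when furan-3-yl or thiophen-2-yl replaces ethynyl.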